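This account rests on a few compounds, and the source may have more. Where it says the series, first, only, none or still open, it means among the compounds named here.

Measured compounds in the series:

- compound 1, `CC(=O)Oc1ccc(/C=C/C(=O)OCCSc2nc(-c3ccc(S(C)(=O)=O)cc3)n(-c3ccc(C(F)(F)F)cc3)n2)cc1OC(C)=O`: 1060 nM
- compound 2, `CC(=O)Oc1ccc(/C=C/C(=O)OCCCSc2nc(-c3ccc(S(N)(=O)=O)cc3)n(-c3ccc(F)cc3)n2)cc1OC(C)=O`: 1030 nM

Both values come from an assay on cells (strain Sprague-Dawley) for inhibition of Polyunsaturated fatty acid 5-lipoxygenase (Rattus norvegicus), with a stated time of 30 min; a lower number here means a stronger inhibitor, a higher number a weaker inhibitor. Compound 1 gives 1060 nM and compound 2 gives 1030 nM; the two numbers lie within the scatter of each other, so the pair shows no separation. Among the measured compounds shown here, no step between two measured compounds differing in a single place is available.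

Compound 3, `CC(=O)Oc1ccc(/C=C/C(=O)OCCCSc2nc(-c3ccc(S(N)(=O)=O)cc3)n(-c3ccccc3)n2)cc1OC(C)=O`, has not yet been measured. Its difference from compound 2 is hydrogen in place of fluoro on an aromatic carbon, which cut one bond further out reads 4-fluorophenyl to phenyl.

For the measured compounds named here, with no measured step of this kind on record, the expectation for this change in this assay is a step of no more than the scatter in either direction; the step of a 1.1-fold higher number from compound 2 to compound 3 (0.03 log units; within the scatter) is the estimate. Compound 3 is expected at 1100 nM, with a range from 500 nM to 2500 nM.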

Compound 3, half-maximal inhibitory concentration: 1070 nM
For compound 3 the middle estimate is 1.0-fold (0.01 log units) above the measured one, within the range that was stated.
By their numbers in this assay, from the lowest: compounds 2, 1 and 3 (each within the scatter of the next).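

Among the compounds shown here, this is the first single-place comparison: 4-fluorophenyl to phenyl, read in this assay as a 1.0-fold higher number from compound 2 to compound 3 (0.02 log units; within the scatter). At this position, para to a large group, fluoro and hydrogen therefore show no separation, at least on the background shared by compound 2 and compound 3. No supporting data bear on why this exchange leaves the read-out unseparated.

On these data alone, whether a different group at this position, such as chloro, methoxy or an amine, would separate from compound 2 and compound 3 remains open. Compound 1 differs from compound 2 in more than one place, so the separate contributions of the trifluoromethyl group, the sulfonyl substituent and the chain remain unresolved, as does the outcome with a longer chain.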